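The source may report more compounds than this note shows. Statements on the series, on what has been measured and on what is new or still open speak of the compounds shown alone.

Compound 1, `CN(C)c1nc(N[C@H]2CC[C@@H](NC(=O)c3cccc(F)c3)CC2)nc2ccccc12`: 9.5 nM
Compound 2, `CN(C)c1nc(N[C@H]2CC[C@@H](NC(=O)c3cccc(C#N)c3)CC2)nc2ccccc12`: 10 nM

In an assay on HEK293 cells for inhibition of melanin-concentrating hormone receptor 1 (Homo sapiens), read by radioligand binding (a higher number here means a weaker inhibitor, a lower number a stronger inhibitor), compound 2 stands alongside compound 1, the gap between them being a 1.1-fold higher number from compound 1 to compound 2 (0.02 log units; within the scatter). Compound 3, `Cc1cccc(C(=O)N[C@H]2CC[C@@H](Nc3nc(N(C)C)c4ccccc4n3)CC2)c1`, differs from compound 2 by methyl in place of cyano on an aromatic carbon. Going by the values given here, the only measured step that touches this place on the ring is the one from compound 1 to compound 2, a 1.1-fold higher number from compound 1 to compound 2 (0.02 log units; within the scatter), which lies within the scatter. On that basis the step from compound 2 to compound 3 is expected to be small, a 1.2-fold higher number from compound 2 to compound 3 (0.08 log units; within the scatter), with no direction beyond the scatter. Compound 3 is therefore estimated at 12 nM, with a range from 5 nM to 30 nM.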

Compound 3, half-maximal inhibitory concentration: 4.6 nM
For compound 3 the middle estimate is 2.6-fold (0.42 log units) above the measured one, and the stated range ends above it.
By their numbers in this assay, from the lowest: compound 3; then compounds 1 and 2 (each within the scatter of the next).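

Methyl in place of cyano gives a 2.2-fold lower number from compound 2 to compound 3 (0.34 log units; beyond the scatter) in this assay and methyl in place of fluoro gives a 2.1-fold lower number from compound 1 to compound 3 (0.31 log units; beyond the scatter) on the same aromatic carbon. This place, meta to a large group, therefore does respond to the group it carries, though only modestly, which the cyano and fluoro pair alone had not shown. Nothing at hand explains why the methyl compound gives the lower number.

The compounds shown leave open whether ethyl, methoxy or an amine at this place would go the same way as methyl. They also leave open whether methyl on another carbon of this ring would give a similar step.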